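Methyl in place of trifluoromethyl: working notes on cytotoxicity

This account rests on a few compounds, and the source may have more. Where it says the series, first, only, none or still open, it means among the compounds named here.

compound 1 `Cc1ccc(S(=O)(=O)OCCCc2cn(-c3ccc(C(F)(F)F)cc3)nn2)cc1`: > 100000 nM (a limit)
compound 2 `Cc1ccc(S(=O)(=O)OCCCc2cn(-c3cccc(F)c3)nn2)cc1`: > 100000 nM (a limit)

In a functional assay on A549 cells (Homo sapiens) for cytotoxicity, read by MTT assay, with a stated time of 48 h (on this read-out lower numbers stand for stronger inhibition and higher numbers for weaker inhibition), compound 1 gives > 100000 nM as a limit of the assay and not a number. Compound 2 gives > 100000 nM as a limit as well. Among the measured compounds shown here, the only evidence so far is the limit of > 100000 nM in this assay, at which 2 of the 2 values shown sit, and no step between two measured compounds is available, so neither compound gives a number to work from.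

The next compound is compound 3 `Cc1ccc(-n2cc(CCCOS(=O)(=O)c3ccc(C)cc3)nn2)cc1` which differs from compound 1 by methyl in place of trifluoromethyl on an aromatic carbon with methyl in place of trifluoromethyl on an aromatic carbon, para to a large group.

In this assay no step beyond the usual scatter is expected, and this expectation rests on compound 1 at > 100000 nM and on nothing stronger. The estimated change is a number no higher from compound 1 to compound 3 (the limit leaves the size open) and it is expected to stay within the scatter. For compound 3 the expected value is 100000 nM with an estimated range from 50000 nM to 200000 nM and a report of only a limit is the likeliest outcome.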

Compound 3, half-maximal inhibitory concentration: 79900 nM
For compound 3 the middle estimate is 1.3-fold (0.10 log units) above the measured one; low and high end bracket the measured number.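

In this assay, among the compounds shown here, compound 3 gives 79900 nM as a measured number and not a limit, the first number in these notes and a first fixed point for the series. Going by these compounds, for methyl in place of trifluoromethyl on an aromatic carbon, para to a large group, the result is an at least 1.2-fold lower number from compound 1 to compound 3 (0.09 log units; that floor lies within the scatter) and no more than that can be read, as compound 1 carries only a limit and the true size of the step stays open. For 4-methylphenyl in place of 3-fluorophenyl on an aromatic nitrogen, the result is an at least 1.2-fold lower number from compound 2 to compound 3 (0.09 log units; that floor lies within the scatter) and the same caution holds, so neither change is shown to matter beyond the scatter, though neither is shown to be without effect.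

Open, on these data alone, is whether an amine or a carboxylic acid on that aromatic carbon, or a longer chain on the core of compound 3, would give a number far from that of compound 3. Also open is how far apart the compounds at the ceiling truly lie, and the values so far rest largely on one limit: the limit of > 100000 nM in this assay, at which 2 of the 3 values shown sit.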